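Nitro for bromo on the thiophene-borne phenyl ring

A few compounds are considered here, and "the series" means these few. Any claim that something is new, unique, unknown or untested is made for them only; others in the source may bear on it.

Measured so far, in a functional assay on CHO cells for agonist activity at adenosine receptor A1 (Homo sapiens), read by fluorescence and ERK phosphorylation, with stated times of 30 min and 1.5 h, tested at 3 uM; a lower number here means a weaker effect, a higher number a stronger effect of the compound at the concentration tested:
compound 1, `Nc1scc(-c2cccc(Br)c2)c1C(=O)c1ccccc1`, gives 67%
compound 2, `Nc1scc(-c2cccc([N+](=O)[O-])c2)c1C(=O)c1ccccc1`, gives 47%
compound 3, `Nc1scc(-c2cccc(Br)c2)c1C(=O)c1ccc(Cl)cc1`, gives 62%

Compound 1 and compound 2 differ by one change, (nitro in place of bromo on an aromatic carbon), and this change made the step of a number 20 percentage points lower from compound 1 to compound 2 (beyond the scatter). Compound 3 differs from compound 1 by chloro in place of hydrogen on an aromatic carbon, a change that made the step of a number 5 percentage points lower from compound 1 to compound 3 (within the scatter).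

Compound 4, `Nc1scc(-c2cccc([N+](=O)[O-])c2)c1C(=O)c1ccc(Cl)cc1`, is not yet measured. It differs from compound 3 by nitro in place of bromo on an aromatic carbon, the same change as between compound 1 and compound 2. Because that earlier change gave a number 20 percentage points lower from compound 1 to compound 2 (beyond the scatter), a step of similar size, a number 20 percentage points lower from compound 3 to compound 4 (beyond the scatter), is expected here, starting from the value of compound 3. Compound 4 is therefore estimated to give 42%, with a likely range from 27% to 57%.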

Compound 4, a percentage reported as activity, at one concentration (the size of the read-out at that concentration, not a potency): 53%
Beside the measured number, compound 4's estimate is 11 percentage points below it; low and high end bracket the measured number.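

With the chloro group present, nitro in place of bromo gives a number 9 percentage points lower from compound 3 to compound 4 (within the scatter), and this step cannot be told apart from the one on the core of compound 1: the same change on two cores in this assay, a number 20 percentage points lower (beyond the scatter) from compound 1 to compound 2 and a number 9 percentage points lower (within the scatter) from compound 3 to compound 4, 11 percentage points apart, within the scatter of two such steps. Chloro in place of hydrogen gives a number 6 percentage points higher from compound 2 to compound 4 (within the scatter), and this step also reads the same on both cores: the same change on two cores in this assay, a number 5 percentage points lower (within the scatter) from compound 1 to compound 3 and a number 6 percentage points higher (within the scatter) from compound 2 to compound 4, 11 percentage points apart, within the scatter of two such steps. The numbers fit a change that carries from one core to the other, but two pairs of compounds do not fix the size of either step or show that it would hold on further cores.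

From the compounds shown here alone, whether an amine or a carboxylic acid in place of bromo would follow the nitro group remains open. Going by these compounds, whether the effect would be stronger or weaker at other concentrations also remains open, as this assay gives the size of the effect at a single concentration.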